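Hydroxymethyl for ethoxycarbonyl on the chloroacetamide compound

The compounds below may be only part of what the source reports. "The series", "measured", "known", "first", "only" and "open" are said of these compounds alone.

Of this series, two compounds carry numbers in a functional assay on Rec1 cells (Homo sapiens) for inhibition, read by luminescence and CellTiter-Glo, with a stated time of 72 h; on this read-out lower numbers stand for stronger inhibition and higher numbers for weaker inhibition. Compound 1 `C=CC(=O)Nc1ccc(Cn2nc(-c3ccc(Oc4ccccc4)cc3)cc2CO)cc1` gives 3500 nM in this assay. Compound 2 `CCOC(=O)c1cc(-c2ccc(Oc3ccccc3)cc2)nn1Cc1ccc(NC(=O)CCl)cc1` gives 400 nM in this assay, the lower of the two numbers; the gap to compound 1 lies beyond the usual scatter, but the two structures differ in more than one place, so nothing is inferred from the pair beyond what the two values show.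

Compound 3 `O=C(CCl)Nc1ccc(Cn2nc(-c3ccc(Oc4ccccc4)cc3)cc2CO)cc1` is not yet measured. It differs from compound 2 in one place: hydroxymethyl in place of ethoxycarbonyl on an aromatic carbon. Within the data shown here, compound 3 shares its hydroxymethyl with compound 1 and its chloroacetamide with compound 2; no measured step isolates the hydroxymethyl for ethoxycarbonyl exchange, so the direction of the change rests on the weak showing of compound 1 alone.

Among the measured compounds shown here, a step upward, toward weaker inhibition, is expected from compound 2 to compound 3 in this assay, of size a 3.8-fold higher number from compound 2 to compound 3 (0.57 log units; beyond the scatter), since the only hydroxymethyl compound measured, compound 1, gives 3500 nM. Compound 3 is estimated at 1500 nM in this assay, within a range from 400 nM to 6000 nM.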

Compound 3, half-maximal inhibitory concentration: 400 nM
For compound 3 the middle estimate is 3.8-fold (0.57 log units) above the measured one; the range from low to high includes it.
By their numbers in this assay, from the lowest: compounds 2 and 3 (each within the scatter of the next); then compound 1.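

On the chloroacetamide compounds in this assay, hydroxymethyl in place of ethoxycarbonyl on this aromatic carbon, next to the ring nitrogen, gives no change at the digits printed from compound 2 to compound 3 (within the scatter), so at this position the two groups cannot be told apart by this read-out. Among these compounds, with hydroxymethyl held fixed, chloromethyl in place of vinyl on the carbonyl carbon gives an 8.8-fold lower number from compound 1 to compound 3 (0.94 log units; beyond the scatter); in the single-change steps available, the only step beyond the scatter therefore lies at the carbonyl end and not at this aromatic carbon. Nothing at hand accounts for either step.

The compounds shown leave open whether this aromatic carbon tolerates groups other than these two, such as a carboxylic acid, an aminomethyl group or a longer alkoxycarbonyl chain, as the two groups seen so far give no trend to extend. They also leave open whether the exchange of ethoxycarbonyl for hydroxymethyl reads the same when vinyl, rather than chloromethyl, sits on the carbonyl carbon.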